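Amide nitrogen substituent in the diazabicyclic nicotinamide series

The source may hold more compounds than are shown below. What is called first, only, known or untested is meant among the compounds shown, and "the series" means these compounds.

Measured so far:
compound 1 `O=C(Nc1ccc(I)cc1)c1cncc(N2CC3CC(C2)N3)c1` — 103 nM
compound 2 `O=C(Nc1ccccc1)c1cncc(N2CC3CC(C2)N3)c1` — 192 nM

In an assay on cells for displacement of a labelled ligand from Neuronal acetylcholine receptor; alpha3/beta4 (Homo sapiens) (a higher number here means a weaker inhibitor, a lower number a stronger inhibitor), compound 1 gives 103 nM and compound 2 gives 192 nM. Among the compounds with values here, compound 2 holds the highest of the two numbers in hand; its only neighbour is compound 1, and the step of a 1.9-fold higher number from compound 1 to compound 2 (0.27 log units; within the scatter) lies within the usual scatter, so the two compounds are not separated in this assay.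

Compound 3 `O=C(NCc1ccccc1)c1cncc(N2CC3CC(C2)N3)c1` is not yet measured. It differs from compound 2 by benzyl in place of phenyl on an amide-type nitrogen. Within the data shown here, the single measured step, a 1.9-fold higher number from compound 1 to compound 2 (0.27 log units; within the scatter), concerns a substituent on the aromatic ring and bears only indirectly on a change at the amide-type nitrogen; it shows the series tolerating a small change there without a shift beyond the scatter. Among the measured compounds shown here, no measured step addresses the amide-type nitrogen itself, so the direction of the change is open.

Compound 3 is expected to give 400 nM in this assay, with a range from 120 nM to 1500 nM. This corresponds to an expected step of a 2.1-fold higher number from compound 2 to compound 3 (0.32 log units; beyond the scatter), a rise in number that may or may not exceed the scatter.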

Compound 3, inhibition constant: 1600 nM
Estimate against measurement, compound 3: 4.0-fold (0.60 log units) below; measured number outside the range, above it.
By their numbers in this assay, from the lowest: compounds 1 and 2 (each within the scatter of the next); then compound 3.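

In this assay, the amide-type nitrogen is the place in this series where a change clearly separates compounds: benzyl in place of phenyl gives an 8.3-fold higher number from compound 2 to compound 3 (0.92 log units; beyond the scatter), and benzyl in place of 4-iodophenyl gives a 16-fold higher number from compound 1 to compound 3 (1.19 log units; beyond the scatter), whereas hydrogen in place of iodo on the aromatic carbon stayed within the scatter. The size of the first step stands out against how little the group changes on paper, with 6 heavy atoms leaving and 7 entering, the six-membered aromatic ring of carbon kept, and no hydrogen-bond donor or acceptor counted on either group, so this position does not tolerate every small change. No measurement at hand bears on why the number rises.

The compounds shown leave open whether the rise continues or reverses with a longer chain such as phenethyl, and how a small non-aromatic group such as methyl or cyclohexyl behaves on the same nitrogen. As far as these compounds go, it also remains open whether iodo on the ring of the benzyl group would leave the number unchanged, as it does within the scatter on the phenyl group.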